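Methyl for cyano on the pyridine of compound 1

This account rests on a few compounds, and the source may have more. Where it says the series, first, only, none or still open, it means among the compounds named here.

Compound 1 `N#Cc1ccc(N2CC[C@@H](NC(=O)Nc3ccccc3Br)C2)nc1` is one of three ureas sharing a core that differs only in the aryl group on the pyrrolidine nitrogen. Going by the values given here, in a functional assay for antagonist activity at transient receptor potential cation channel subfamily V member 1 (Rattus norvegicus), read by FLIPR (a higher number here means a more potent compound, by a factor of ten per unit of this negative logarithm, a lower number a less potent compound), compound 1 gives 6.7, the lower of the two numbers known. Compound 3 `O=C(Nc1ccccc1Br)N[C@@H]1CCN(c2ncccc2C(F)(F)F)C1` gives 7.1 in this assay, a gap beyond the usual scatter. Compound 2 `Cc1cccc(N2CC[C@H](NC(=O)Nc3ccccc3Br)C2)c1` is known in this assay only as a limit, < 6.8. Compound 4 `Cc1ccc(N2CC[C@@H](NC(=O)Nc3ccccc3Br)C2)nc1` has not been measured; it differs from compound 1 by methyl in place of cyano on an aromatic carbon. Among the compounds with values here, no step between measured compounds shows this change, so compound 4 is expected to sit close to compound 1, with a step of a number 0.10 log units lower from compound 1 to compound 4 (within the scatter). The estimate for compound 4 is 6.6, from 6 to 7.2.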

Compound 4, negative logarithm of the antagonist equilibrium constant: < 6.7
Compound 4: no number, only a limit; the forecaster's own chance of this, stated with the estimate: 30%; the middle value is on the limit's open side.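

In this assay compound 4 gives < 6.7, which is a limit and not a number. The step from 5-cyanopyridin-2-yl to 5-methylpyridin-2-yl is a number no higher from compound 1 to compound 4 (the limit leaves the size open). It shows only that methyl in place of cyano at this position brings no higher number, the first reading of any change here: the limit of < 6.7 in this assay, at which 1 of the 4 values shown sits.

The compounds shown leave open where compound 4 actually stands in this assay. They also leave open what an amine or a carboxylic acid on this aromatic carbon would give.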